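Thiophen-3-yl in place of furan-2-yl on a carbonyl carbon

The source may hold more compounds than are shown below. What is called first, only, known or untested is meant among the compounds shown, and "the series" means these compounds.

Measured in a functional assay on HCT-15 cells (Homo sapiens) for inhibition, read by colorimetric assay and sulforhodamine B assay, with a stated time of 48 h; a lower number here means a stronger inhibitor of growth, a higher number a weaker inhibitor of growth:
compound 1 `CCCCCCCCCCCC[C@@H](O)[C@H]1CC[C@H]([C@H](O)CCCCCCCCCCNC(=O)c2cccs2)O1` gives 5750 nM
compound 2 `CCCCCCCCCCCC[C@@H](O)[C@H]1CC[C@H]([C@H](O)CCCCCCCCCCNC(=O)c2ccco2)O1` gives 100000 nM
compound 3 `CCCCCCCCCCCC[C@@H](O)[C@H]1CC[C@H]([C@H](O)CCCCCCCCCCNC(=O)c2cncs2)O1` gives 100000 nM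

Compound 2 stands level with compound 3, and together they hold the highest of the three numbers. Compound 1 lies far lower, as the large step of a 17-fold higher number from compound 1 to compound 2 (1.24 log units; beyond the scatter) shows.

Compound 4 `CCCCCCCCCCCC[C@@H](O)[C@H]1CC[C@H]([C@H](O)CCCCCCCCCCNC(=O)c2ccsc2)O1` is not yet measured. It differs from compound 2 by one change (thiophen-3-yl in place of furan-2-yl on a carbonyl carbon): thiophen-3-yl in place of furan-2-yl on a carbonyl carbon

The closest evidence is that same large step a 17-fold higher number from compound 1 to compound 2 (1.24 log units; beyond the scatter) (furan-2-yl in place of thiophen-2-yl). Read in reverse, it points towards a lower number for a thiophene. The step of a 17-fold higher number from compound 1 to compound 3 (1.24 log units; beyond the scatter) is equally large, and no change at the digits printed from compound 2 to compound 3 (within the scatter) lies within the scatter, so a lower number is not shared by every ring tried. For the measured compounds named here, no thiophen-3-yl compound has been measured, so only part of that gap is expected to carry over in this assay.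

The expected step, towards a lower number, is an 8.3-fold lower number from compound 2 to compound 4 (0.92 log units; beyond the scatter) (a wide uncertainty applies). The estimate for compound 4 is 12000 nM (expected range 3000 nM to 100000 nM).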

Compound 4, concentration for 50% growth inhibition: 38000 nM
Compound 4: middle estimate off by 3.2-fold (0.50 log units), on the low side; low and high end bracket the measured number.
By their numbers in this assay, from the lowest: compound 1; then compound 4; then compounds 2 and 3 (each within the scatter of the next).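

In this assay, swapping the thiophen-2-yl ring for a thiophen-3-yl ring gives a 6.6-fold higher number from compound 1 to compound 4 (0.82 log units; beyond the scatter), so within this pair the point of attachment of the thiophene matters and a thiophene ring alone does not reproduce the number of compound 1. The thiophen-3-yl amide still stands apart from the other two rings, with a 2.6-fold lower number from compound 2 to compound 4 (0.42 log units; beyond the scatter) and a 2.6-fold lower number from compound 3 to compound 4 (0.42 log units; beyond the scatter), placing it in an intermediate position among these four compounds. Nothing available bears on why the two thiophene attachments differ.

Open, from the compounds shown here alone, is whether a phenyl or pyridin-2-yl ring on the same carbonyl carbon, or a chlorine on the thiophen-2-yl ring, would match or improve on compound 1. Also open is whether the order among these rings holds with a shorter chain carrying the amide.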